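Swapping the Aryl Group on the Amine Nitrogen

The source may hold more compounds than are shown below. What is called first, only, known or untested is meant among the compounds shown, and "the series" means these compounds.

Compound 1 `CCOC(=O)C1=C(Nc2ccccc2)S/C(=C\c2ccccc2O)C1=O` gives 8000 nM in a functional assay on JAR cells (Homo sapiens) for inhibition, read by MTT assay, with a stated time of 72 h; a lower number here means a stronger inhibitor, a higher number a weaker inhibitor.
Compound 2 `CCOC(=O)C1=C(Nc2ccc(Br)cc2)S/C(=C\c2ccc[nH]2)C1=O` gives 27000 nM in this assay.

Of the two measured compounds, compound 2 has the higher number and is thus the weaker inhibitor, and its gap to compound 1 lies beyond the usual scatter of repeated measurements. The two differ in more than one place, so no single change can be tied to that gap.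

Compound 3 `CCOC(=O)C1=C(Nc2cccc([N+](=O)[O-])c2)S/C(=C\c2ccc[nH]2)C1=O` has not yet been measured. It differs from compound 2 in one place: 3-nitrophenyl in place of 4-bromophenyl on an amine nitrogen. Going by the values given here, no measured pair shows what this exchange does on its own, so there is no footing for a direction. The step of a 1.2-fold lower number from compound 2 to compound 3 (0.09 log units; within the scatter) is therefore expected to stay within the scatter. The estimate for compound 3 is 22000 nM, with a range from 6000 nM to 80000 nM.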

Compound 3, half-maximal inhibitory concentration: 10100 nM
The estimate for compound 3 lay 2.2-fold (0.34 log units) above the measured number; the measured number falls inside the stated range.
By their numbers in this assay, from the lowest: compounds 1 and 3 (each within the scatter of the next); then compound 2.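

In this assay, going by these compounds alone, the group on the amine nitrogen proves able to move the number: with the rest of the molecule unchanged, 3-nitrophenyl in place of 4-bromophenyl gives a 2.7-fold lower number from compound 2 to compound 3 (0.43 log units; beyond the scatter) and is the first change here that can be read on its own. The step is modest, but it lies beyond the usual scatter. Nothing at hand gives a reason for it.

Within the data shown here, this exchange replaces the bromine with a nitro group and also changes where the group sits on the phenyl ring, so the single step cannot separate the two changes. A 3-bromophenyl or 4-nitrophenyl group would be needed to pull them apart, while an amino or carboxylic acid group on the ring would show how far this position tolerates other kinds of group.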